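Benzyl ring chloro removal in a triazolopyrimidine series

A few compounds are considered here, and "the series" means these few. Any claim that something is new, unique, unknown or untested is made for them only; others in the source may bear on it.

Measured so far in an assay on isolated protein for binding affinity to adenosine receptor A1 (Bos taurus); on this read-out higher numbers stand for weaker inhibition and lower numbers for stronger inhibition:
compound 1 `CCCNc1nc(-c2ccccc2)nc2c1nnn2Cc1ccccc1` gives 37000000 nM
compound 2 `Clc1ccccc1Cn1nnc2c(NC3CCCC3)nc(-c3ccccc3)nc21` gives 9000000 nM
compound 3 `CCNc1nc(-c2ccccc2)nc2c1nnn2Cc1ccccc1Cl` gives 463000000 nM

Compound 2 stands lowest of the three numbers in this assay; compound 1 lies nearest to it and compound 3 furthest. Among the compounds with values here, the only single-point step measured, a 51-fold higher number from compound 2 to compound 3 (1.71 log units; beyond the scatter), concerns ethyl in place of cyclopentyl on a nitrogen on an aromatic ring and leaves the 2-chlorobenzyl group untouched.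

Compound 4 `c1ccc(Cn2nnc3c(NC4CCCC4)nc(-c4ccccc4)nc32)cc1` differs from compound 2 by hydrogen in place of chloro on an aromatic carbon. Within the data shown here, no measured pair isolates this change: compound 1 carries a plain benzyl but also propyl instead of cyclopentyl, so its value against compound 2 mixes two differences. The step from compound 2 to compound 3 therefore does not bear on the chloro removal, and no size for that change can be read from the set.

With nothing to anchor it, the step of a 1.7-fold higher number from compound 2 to compound 4 (0.22 log units; within the scatter) is expected to be small, most likely within or just beyond the scatter, leaning toward a higher number. Compound 4 is estimated at 15000000 nM, with a range from 4000000 nM to 60000000 nM.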

Compound 4, inhibition constant: 11000000 nM
Compound 4: middle estimate off by 1.4-fold (0.13 log units), on the high side, and the stated range covers the measured number.
By their numbers in this assay, from the lowest: compounds 2 and 4 (each within the scatter of the next); then compound 1; then compound 3.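

In this assay, hydrogen and chloro on this aromatic carbon cannot be told apart when cyclopentyl sits on the nitrogen (a 1.2-fold higher number from compound 2 to compound 4 (0.09 log units; within the scatter)), so the 2-chlorobenzyl and benzyl groups read alike in this pair. Within the data shown here, compound 4 also gives the first single-change reading for the nitrogen substituent with a plain benzyl (a 3.4-fold lower number from compound 1 to compound 4 (0.53 log units; beyond the scatter)), and it runs in the same direction as the step with the 2-chlorobenzyl group (a 51-fold higher number from compound 2 to compound 3 (1.71 log units; beyond the scatter)), with the cyclopentyl compound holding the lower number in both pairs. No available data explain either the flat chloro step or the nitrogen substituent steps.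

Going by these compounds, whether chloro and hydrogen also read alike with ethyl or propyl on the nitrogen remains open. So does the outcome of placing a methoxy, an amine or a carboxylic acid on this aromatic carbon.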